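Permeability notes on the shared core series: oxolanyl for hydroxyethyl

The source may hold more compounds than are shown below. What is called first, only, known or untested is meant among the compounds shown, and "the series" means these compounds.

Compound 1 `COc1ccc(Cn2c(-c3ccccc3)c(-c3ccccc3)c3c(=N)n(C4CCOCC4)cnc32)cc1` carries no result in an ADME assay for permeability, using PAMPA, with a stated time of 30 min, at pH 7.4 (a higher number here means that the compound crosses the layer faster, a lower number that the compound crosses the layer more slowly), only "nd" (no result reported). Compound 2 `COc1ccc(Cn2c(-c3ccccc3)c(-c3ccccc3)c3c(=N)n(CC4CCOCC4)cnc32)cc1` gives 1270 10^-6 cm/s in this assay. For compound 3 `COc1ccc(Cn2c(-c3ccccc3)c(-c3ccccc3)c3c(=N)n(CCCO)cnc32)cc1` this assay reports only a limit, > 1000 10^-6 cm/s. Compound 3 therefore stands without a single number; it shares this with one further entry in the set, and the step from compound 2 to compound 3 reads as a step that the limit leaves unreadable from compound 2 to compound 3, unreadable due to the limit of > 1000 10^-6 cm/s in this assay, at which 1 of the 3 values shown sits.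

Compound 4 `COc1ccc(Cn2c(-c3ccccc3)c(-c3ccccc3)c3c(=N)n(CC4CCCO4)cnc32)cc1` differs from compound 3 by oxolan-2-yl in place of 2-hydroxyethyl on a saturated chain carbon bound to an aromatic nitrogen. Among the measured compounds shown here, the only measured step that touches this place is the one from compound 2 to compound 3, and its size is hidden by the limit, so no readable step bears on the change. What remains is that compound 2, which carries a ring ether at this place, gives 1270 10^-6 cm/s. Compound 3, for its part, is reported only as a limit of this assay. Both ring ether and open hydroxyl chain thus already fall in the fast range of this assay.

The step from compound 3 to compound 4 is therefore expected to be a step that the limit leaves unreadable from compound 3 to compound 4, within the scatter. Compound 4 is estimated at 1200 10^-6 cm/s, with a range from 600 10^-6 cm/s to 2400 10^-6 cm/s, most likely reported again as a limit.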

Compound 4, apparent permeability: > 1000 10^-6 cm/s
Compound 4: only a limit was reported; the forecaster's own chance of this, stated with the estimate: 60%; the middle value lies beyond the limit too.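

Compound 4 is reported in this assay only as a limit, > 1000 10^-6 cm/s. No new step can be read from compound 4 to compound 2 or compound 3, because the comparison stops at the limit: the limit of > 1000 10^-6 cm/s in this assay, at which 2 of the 4 values shown sit.

The compounds shown leave open how far oxolan-2-yl, 2-hydroxyethyl and oxan-4-yl differ on this saturated chain carbon in this assay.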